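Cytotoxicity notes: amide to amine on the shared core

This account rests on a few compounds, and the source may have more. Where it says the series, first, only, none or still open, it means among the compounds named here.

Among the measured compounds shown here, compound 2 `COC(=O)CC(=O)NC1=CS(=O)(=O)O[C@@]12[C@@H](CO[Si](C)(C)C(C)(C)C)O[C@@H](n1cc(C)c(=O)n(C)c1=O)[C@@H]2O[Si](C)(C)C(C)(C)C` gives 11900 nM in a functional assay on MT4 cells (Homo sapiens) (on this read-out lower numbers stand for higher toxicity in this test and higher numbers for lower toxicity in this test), the lowest of the two numbers so far; the only other measured member, compound 1 `COC(=O)NC1=CS(=O)(=O)O[C@@]12[C@@H](CO[Si](C)(C)C(C)(C)C)O[C@@H](n1cc(C)c(=O)n(C)c1=O)[C@@H]2O[Si](C)(C)C(C)(C)C`, gives 29900 nM, and the step of a 2.5-fold lower number from compound 1 to compound 2 (0.40 log units; beyond the scatter). Compound 3 `COC(=O)CCNC1=CS(=O)(=O)O[C@@]12[C@@H](CO[Si](C)(C)C(C)(C)C)O[C@@H](n1cc(C)c(=O)n(C)c1=O)[C@@H]2O[Si](C)(C)C(C)(C)C` is not yet measured. For the measured compounds named here, its difference from compound 2 2-(methoxycarbonyl)ethyl in place of ((methoxycarbonyl)methyl)carbonyl on an amine nitrogen sits on the same amine nitrogen that the one measured step altered, but that step exchanged one group on a carbonyl carbon for another, whereas here ((methoxycarbonyl)methyl)carbonyl gives way to 2-(methoxycarbonyl)ethyl; no measured pair shows this kind of change. Going by the values given here, the only guidance is that the single known step was modest, so no step beyond the scatter is expected in this assay. Compound 3 is therefore estimated at 15000 nM, with a range from 6000 nM to 40000 nM, a step of a 1.3-fold higher number from compound 2 to compound 3 (0.10 log units; within the scatter) that is expected to stay within the scatter.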

Compound 3, half-maximal cytotoxic concentration: > 250000 nM
Compound 3: no number, only a limit; the forecaster's own chance of this, stated with the estimate: 10%; middle value at least 16-fold (1.22 log units) from the limit.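

On the amine nitrogen, the earlier step only varied what sat on the carbonyl carbon, whereas removing that carbonyl from the nitrogen has a far larger effect in this assay: 2-(methoxycarbonyl)ethyl in place of ((methoxycarbonyl)methyl)carbonyl gives an at least 21-fold higher number from compound 2 to compound 3 (1.32 log units; beyond the scatter), and 2-(methoxycarbonyl)ethyl in place of methoxycarbonyl gives an at least 8.3-fold higher number from compound 1 to compound 3 (0.92 log units; beyond the scatter). Among these compounds, the two with a carbonyl directly on the amine nitrogen give measured numbers, and compound 3, the only one without it, marks the low-toxicity end of the series. Compound 3 carries a limit of the assay, not a number, so both steps are lower bounds: the limit of > 250000 nM in this assay, at which 1 of the 3 values shown sits.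

As far as these compounds go, it remains open whether a free amine at this nitrogen would behave like compound 3. Also open, from the compounds shown here alone, is what a longer chain, or a carboxylic acid in place of the methoxycarbonyl end, would do there.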